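The source may hold more compounds than are shown below. What is called first, only, known or untested is meant among the compounds shown, and "the series" means these compounds.

Of the compounds shown here, three built on a shared core have been measured in a functional assay on cells (Cancer cell lines, Homo sapiens) for inhibition; on this read-out higher numbers stand for weaker inhibition of growth and lower numbers for stronger inhibition of growth. Compound 1, `COc1ccc(-c2nc3sc(Cc4ccccc4)nn3c2SC#N)cc1`, gives 3900 nM. Compound 2, `Clc1ccc(-c2cn3nc(Cc4ccccc4)sc3n2)cc1`, gives 5000 nM. Compound 3, `O=Cc1c(-c2ccc(Br)cc2)nc2sc(Cc3ccccc3)nn12`, gives 2200 nM, the lowest of the three numbers; its gap to compound 1 lies within the usual scatter of repeated measurements, while its gap to compound 2 lies beyond it, so only against compound 2 can compound 3 be said to inhibit growth more strongly.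

Going by the values given here, the next compound, compound 4, `O=Cc1c(-c2ccc([N+](=O)[O-])cc2)nc2sc(Cc3ccccc3)nn12`, keeps everything of compound 3 except one substituent on an aromatic carbon of the six-membered aromatic ring of carbon only that hangs off the core: nitro in place of bromo on an aromatic carbon. Among the compounds with values here, no pair of measured compounds shows the effect of this exchange, so the expectation rests on compound 3 alone and on the modest size of the change, which touches a single position and leaves the rest of the molecule untouched. The expected step is small, a 1.1-fold lower number from compound 3 to compound 4 (0.04 log units; within the scatter), in no clear direction and probably not beyond the scatter. Compound 4 is estimated at 2000 nM in this assay, with a likely range from 900 nM to 4500 nM.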

Compound 4, concentration for 50% growth inhibition: 2900 nM
Beside the measured number, compound 4's estimate is 1.5-fold (0.16 log units) below it; measured number inside the range.
By their numbers in this assay, from the lowest: compounds 3, 4, 1 and 2 (each within the scatter of the next, the first and the last beyond it).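

In this assay, nitro in place of bromo on this aromatic carbon, para to a large group, gives a 1.3-fold higher number from compound 3 to compound 4 (0.12 log units; within the scatter), so compound 3 and compound 4 cannot be told apart on this read-out. Going by these compounds alone, this is the first direct view of this position: the exchange replaces one heavy atom with three and adds two hydrogen-bond acceptors, yet the number stays within the scatter. Nothing at hand explains this result.

As far as these compounds go, whether any group on this carbon can shift growth inhibition beyond the scatter remains open, and an amine, a methoxy group or a longer chain such as butyl would extend the test to quite different substituents. Also open, from the compounds shown here alone, is what the aldehyde group of compound 3 and compound 4 contributes, since neither of the other two compounds differs from them in that one place alone, and a single exchange there, such as a carboxylic acid for the aldehyde with the rest of the molecule kept, would address that question.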